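A fluoro added to a nitro-bearing prostacyclin synthase inhibitor

The compounds below may be only part of what the source reports. "The series", "measured", "known", "first", "only" and "open" are said of these compounds alone.

Compound 1 `CC(C)(Oc1ccccc1F)C1OCC(C/C=C\CCC(=O)O)C(c2cccnc2)O1` was examined in an assay for inhibition of prostacyclin synthase (Homo sapiens), using microsomes; a lower number here means a stronger inhibitor, a higher number a weaker inhibitor. In this assay compound 1 gives < 1000 nM, which is a limit of the assay and not a number. Compound 2 `CSc1ccccc1OC(C)(C)C1OCC(C/C=C\CCC(=O)O)C(c2cccnc2)O1` carries methylsulfanyl in place of fluoro on an aromatic carbon; in this assay compound 2 gives > 100000 nM, again only a limit. The exchange yields an at least 100-fold higher number from compound 1 to compound 2 (2.00 log units; beyond the scatter). Compound 3 `CC(C)(Oc1ccccc1[N+](=O)[O-])C1OCC(C/C=C\CCC(=O)O)C(c2cccnc2)O1` carries nitro in place of fluoro on an aromatic carbon; in this assay compound 3 gives < 1000 nM, also a limit. The comparison with compound 1 is a step that the two limits leave unreadable from compound 1 to compound 3, whereas an at least 100-fold lower number from compound 2 to compound 3 (2.00 log units; beyond the scatter). Compound 3 therefore rests at the limit of < 1000 nM in this assay, at which 2 of the 3 values shown sit, and compound 2 at the limit of > 100000 nM in this assay, at which 1 of the 3 values shown sits.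

Compound 4 `CC(C)(Oc1ccc(F)cc1[N+](=O)[O-])C1OCC(C/C=C\CCC(=O)O)C(c2cccnc2)O1` differs from compound 3 by fluoro in place of hydrogen on an aromatic carbon. None of the three measured steps touches this place: each exchanges fluoro, methylsulfanyl or nitro against one another and leaves the spot of the added fluoro unchanged, so they offer no direct guide. With compound 3 known only as a limit, the expectation is a step that stays within the scatter, a step that the limit leaves unreadable from compound 3 to compound 4. The estimate for compound 4 in this assay is 500 nM, expected to lie between 100 nM and 3000 nM.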

Compound 4, half-maximal inhibitory concentration: 9000 nM
Estimate against measurement, compound 4: 18-fold (1.26 log units) below, outside the stated range (above it).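

In this assay, within the data shown here, fluoro in place of hydrogen on the ring carbon meta to a nitro group and para to a large group gives an at least 9.0-fold higher number from compound 3 to compound 4 (0.95 log units; beyond the scatter), so this position, untouched by the earlier steps, does not tolerate every change without consequence. From the compounds shown here alone, the true size of this step stays unknown, since compound 3 is known only as a limit: the limit of < 1000 nM in this assay, at which 2 of the 4 values shown sit. The 4-fluoro-2-nitrophenyl group lies between the two other groups compared with it: in place of 2-(methylsulfanyl)phenyl it gives an at least 11-fold lower number from compound 2 to compound 4 (1.04 log units; beyond the scatter), and in place of 2-fluorophenyl it gives an at least 9.0-fold higher number from compound 1 to compound 4 (0.95 log units; beyond the scatter).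

Going by these compounds, whether a chloro or a methoxy group at this place would behave like fluoro remains open. So does whether fluoro here would give a similar step with fluoro rather than nitro on the ring.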